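Replacing a thiolane with an oxolane ring

A few compounds are considered here, and "the series" means these few. Any claim that something is new, unique, unknown or untested is made for them only; others in the source may bear on it.

Compound 1, `CC(C)C[C@H](N)c1cc(C(F)(F)F)ccc1N1CCN(C(=O)[C@H]2CSC[C@@H]2c2ccc(Cl)cc2)CC1`, gives 280 nM in an assay on HEK293 cells for displacement of a labelled ligand from Melanocortin receptor 4 (Homo sapiens); on this read-out lower numbers stand for stronger inhibition and higher numbers for weaker inhibition.
Compound 2, `CC(C)C[C@H](N)c1cc(C(F)(F)F)ccc1N1CCN(C(=O)[C@H]2CCO[C@@H]2c2ccc(Cl)cc2)CC1`, gives 330 nM in this assay.
Compound 3, `CC(C)C[C@H](NC(=O)CCN(C)C)c1cc(C(F)(F)F)ccc1N1CCN(C(=O)[C@H]2CSC[C@@H]2c2ccc(Cl)cc2)CC1`, gives 130 nM in this assay.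

Among the measured compounds shown here, of the three numbers measured so far, compound 3 has the lowest; the step from its parent amine is a 2.2-fold lower number from compound 1 to compound 3 (0.33 log units; beyond the scatter), and compound 2 sits further away still.

Compound 4, `CC(C)C[C@H](NC(=O)CCN(C)C)c1cc(C(F)(F)F)ccc1N1CCN(C(=O)[C@H]2CCO[C@@H]2c2ccc(Cl)cc2)CC1`, differs from compound 3 in one place: 2-(4-chlorophenyl)oxolan-3-yl in place of 4-(4-chlorophenyl)thiolan-3-yl on a carbonyl carbon. The same exchange has already been made once in this set, on the pair without the (2-(dimethylamino)ethyl)carbonyl group: there it gave a 1.2-fold higher number from compound 1 to compound 2 (0.07 log units; within the scatter). For the measured compounds named here, that earlier step is the only direct guide, and it showed no change beyond the scatter, so the expectation for compound 4 is a number close to that of compound 3, with at most a small drift upward.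

On that basis compound 4 is expected to give about 150 nM in this assay, with a range from 70 nM to 320 nM. The estimated step is a 1.2-fold higher number from compound 3 to compound 4 (0.06 log units; within the scatter), which is expected to stay within the scatter.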

Compound 4, inhibition constant: 200 nM
The estimate for compound 4 lay 1.3-fold (0.12 log units) below the measured number; the range from low to high includes it.
By their numbers in this assay, from the lowest: compounds 3, 4, 1 and 2 (each within the scatter of the next, the first and the last beyond it).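

Swapping 4-(4-chlorophenyl)thiolan-3-yl for 2-(4-chlorophenyl)oxolan-3-yl on the carbonyl carbon has now been read on a second core, where a 1.5-fold higher number from compound 3 to compound 4 (0.19 log units; within the scatter) also stays inside the scatter of this assay, so the two groups cannot be told apart on either core: the same change on two cores in this assay, a 1.2-fold higher number (0.07 log units; within the scatter) from compound 1 to compound 2 and a 1.5-fold higher number (0.19 log units; within the scatter) from compound 3 to compound 4, 1.3-fold (0.12 log units) apart, within the scatter of two such steps.
The (2-(dimethylamino)ethyl)carbonyl group on the amine nitrogen gives a 1.7-fold lower number from compound 2 to compound 4 (0.22 log units; within the scatter), so the step that lay beyond the scatter on the core of compound 1 does not clear it on the core of compound 2, although the two steps do not differ from each other beyond the scatter: the same change on two cores in this assay, a 2.2-fold lower number (0.33 log units; beyond the scatter) from compound 1 to compound 3 and a 1.7-fold lower number (0.22 log units; within the scatter) from compound 2 to compound 4, 1.3-fold (0.12 log units) apart, within the scatter of two such steps.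
Across these four compounds, then, the size of each change shows no clear dependence on the other, and the effect of the (2-(dimethylamino)ethyl)carbonyl group is supported less firmly than compound 3 alone suggested.

The compounds shown leave open whether a ring nitrogen in place of the sulfur or oxygen would also leave the number unchanged.
They also leave open how a longer chain between the carbonyl and the dimethylamino group, or a carboxylic acid in place of that amine, would read in this assay.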